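This account rests on a few compounds, and the source may have more. Where it says the series, first, only, none or still open, it means among the compounds named here.

Measured so far in a functional assay on A-375 cells (Homo sapiens) for cytotoxicity, read by MTT assay, with a stated time of 72 h, tested at 3 uM; a lower number here means less inhibition of growth, a higher number more inhibition of growth at the concentration tested:

Compound 1 `Cc1ccnc(/C(N)=N/NC(=S)N2CCOCC2)c1` gives 66.6%.
Compound 2 `Cc1ccnc(/C(N)=N/NC(=S)N2CCSCC2)c1` gives 67.2%.
Compound 3 `N/C(=N\NC(=S)N1CCSCC1)c1ccc(F)cn1` gives 62.2%.

Compound 1 and compound 2 share one core and differ in a single place: morpholin-4-yl in place of thiomorpholin-4-yl on a thiocarbonyl carbon. In this assay that change made a step of a number 0.6 percentage points lower from compound 2 to compound 1 (within the scatter). Compound 3 rests on a different core; how the two cores differ is not broken down here. All three values lie within the usual scatter of one another, so no order among them can be read.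

Compound 4 `N/C(=N\NC(=S)N1CCOCC1)c1ccc(F)cn1` has not yet been measured. It comes from compound 3 by the same change, at the same kind of place: morpholin-4-yl in place of thiomorpholin-4-yl on a thiocarbonyl carbon. The step from compound 3 to compound 4 is expected to be small, a number 0.2 percentage points lower from compound 3 to compound 4 (within the scatter), because the earlier step of a number 0.6 percentage points lower from compound 2 to compound 1 (within the scatter) stayed within the scatter. Compound 4 is therefore estimated at 62%, with four of five repeat measurements expected between 50% and 74%.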

Compound 4, percent growth inhibition at one concentration: 66.4%
Estimate against measurement, compound 4: 4.4 percentage points below; low and high end bracket the measured number.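

In this assay putting morpholin-4-yl in place of thiomorpholin-4-yl on a thiocarbonyl carbon gives a number 4.2 percentage points higher from compound 3 to compound 4 (within the scatter) on this core. Set beside the same change on the other core, the new step does not stand apart: the same change on two cores in this assay, a number 0.6 percentage points lower (within the scatter) from compound 2 to compound 1 and a number 4.2 percentage points higher (within the scatter) from compound 3 to compound 4, 4.8 percentage points apart, within the scatter of two such steps. On these two cores, then, the exchange of the two rings leaves growth inhibition indistinguishable from the usual scatter, but two pairs of compounds cannot show that this holds on other cores or that the change has no effect at all.

All four compounds carry one of these two rings on the thiocarbonyl carbon. As far as these compounds go, what piperidin-1-yl or an open-chain amine such as dimethylamino would do at that place remains open.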